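The source may hold more compounds than are shown below. What is called first, only, known or untested is meant among the compounds shown, and "the series" means these compounds.

Among the measured compounds shown here, compound 3 `Cc1cc(-c2ccccc2)n(/C(N)=N/S(=O)(=O)c2cc(C)c(Cl)cc2SCc2ccccc2C(F)(F)F)n1` gives 215000 nM in a functional assay on HeLa cells (Homo sapiens) for cytotoxicity, read by MTT assay, with a stated time of 72 h (a lower number here means a stronger inhibitor, a higher number a weaker inhibitor), the highest of the three numbers measured so far. Its closest neighbour is compound 2 `Cc1cc(-c2ccccc2)n(/C(N)=N/S(=O)(=O)c2cc(C)c(Cl)cc2SCc2ccccc2C)n1`, which gives 160000 nM; the two differ only by a 1.3-fold higher number from compound 2 to compound 3 (0.13 log units; within the scatter). Compound 1 `Cc1cc(S(=O)(=O)/N=C(\N)n2nccc2-c2ccccc2)c(SCc2ccc(Cl)cc2)cc1Cl` is built differently at the core and gives 3000 nM, a number far lower than that of compound 3.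

Compound 4 `Cc1cc(-c2ccccc2)n(/C(N)=N/S(=O)(=O)c2cc(C)c(Cl)cc2SCc2ccc(C(F)(F)F)cc2)n1` has the same atoms as compound 3, joined differently: 4-(trifluoromethyl)phenyl in place of 2-(trifluoromethyl)phenyl on a saturated chain carbon bound to a sulfur. For the measured compounds named here, no measured pair shows what happens when the trifluoromethyl moves from one position to another on that ring. Going by the values given here, the only step that comes near, methyl to trifluoromethyl, stayed within the scatter, and the gap to compound 1 comes with other changes that cannot be separated. Among the compounds with values here, with no measured step bearing on this change, compound 4 is expected to give about 180000 nM, within 60000 nM to 500000 nM, and the expected step of a 1.2-fold lower number from compound 3 to compound 4 (0.08 log units; within the scatter) is not beyond the scatter.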

Compound 4, half-maximal inhibitory concentration: 19000 nM
Compound 4: middle estimate off by 9.5-fold (0.98 log units), on the high side; measured number outside the range, below it.
By their numbers in this assay, from the lowest: compound 1; then compound 4; then compounds 2 and 3 (each within the scatter of the next).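

In this assay, moving the trifluoromethyl from 2-(trifluoromethyl)phenyl to 4-(trifluoromethyl)phenyl on a saturated chain carbon bound to a sulfur produces a step beyond the scatter (an 11-fold lower number from compound 3 to compound 4 (1.05 log units; beyond the scatter)), whereas the earlier change from methyl to trifluoromethyl did not (a 1.3-fold higher number from compound 2 to compound 3 (0.13 log units; within the scatter)). So at this site, where the trifluoromethyl sits on the ring counts for far more than the swap of methyl for trifluoromethyl, and replacing 2-methylphenyl with 4-(trifluoromethyl)phenyl also gives a step beyond the scatter (an 8.4-fold lower number from compound 2 to compound 4 (0.93 log units; beyond the scatter)). Nothing available explains why the ring position has this effect.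

Compound 1 differs from compound 4 in more than one place, so the gap between them cannot be read as a single step. On these data alone, whether a nitrile or a carboxylic acid could replace the trifluoromethyl in 4-(trifluoromethyl)phenyl and keep the lower number remains open.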